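A few compounds are considered here, and "the series" means these few. Any claim that something is new, unique, unknown or untested is made for them only; others in the source may bear on it.

Of the compounds shown here, three sharing one core have so far been measured in a functional assay on MCF7 cells (Homo sapiens) for antiproliferative activity, read by XTT assay, with a stated time of 72 h; a lower number here means a stronger inhibitor, a higher number a weaker inhibitor. Compound 1 `COc1ccc(-c2cc3ccccc3nc2/C=C/C(=O)c2ccccc2)cc1` gives 4040 nM. Compound 2 `COc1ccc(-c2cc3ccccc3nc2/C=C/C(=O)c2c(OC)cccc2OC)cc1`, which carries a 2,6-dimethoxyphenyl instead of a phenyl on the carbonyl carbon, gives 4520 nM; that exchange is a 1.1-fold higher number from compound 1 to compound 2 (0.05 log units; within the scatter). Compound 3 `COc1ccc(-c2cc3ccccc3nc2/C=C/C(=O)c2ccc(Br)s2)cc1`, with a 5-bromothiophen-2-yl on the carbonyl carbon, gives 910 nM, the lowest of the three numbers. The steps leading to it are a 4.4-fold lower number from compound 1 to compound 3 (0.65 log units; beyond the scatter) and a 5.0-fold lower number from compound 2 to compound 3 (0.70 log units; beyond the scatter), both beyond the scatter and modest in size.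

Compound 4 `COc1ccc(-c2cc3ccccc3nc2/C=C/C(=O)c2sccc2N)cc1` differs from compound 3 in one place: 3-aminothiophen-2-yl in place of 5-bromothiophen-2-yl on a carbonyl carbon. Going by the values given here, no measured step swaps one thiophene for another; the two steps to compound 3 only show that replacing a phenyl or a 2,6-dimethoxyphenyl by the 5-bromothiophen-2-yl lowered the number. Whether the 3-aminothiophen-2-yl keeps that gain is not shown. The step expected from compound 3 to compound 4 in this assay is a 2.7-fold higher number from compound 3 to compound 4 (0.44 log units; beyond the scatter), leaning toward a somewhat higher number with a wide range. Compound 4 is estimated to give 2500 nM, between 800 nM and 8000 nM.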

Compound 4, half-maximal inhibitory concentration: > 10000 nM
Compound 4 ended at the assay's limit; the forecaster's own chance of this, stated with the estimate: 5%; middle value at least 4.0-fold (0.60 log units) away from the limit.
By their numbers in this assay, from the lowest: compound 3; then compounds 1 and 2 (each within the scatter of the next). At a limit, above all of these: compound 4.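

A thiophene on the carbonyl carbon does not by itself hold the low number of compound 3: this exchange gives an at least 10-fold higher number from compound 3 to compound 4 (1.04 log units; beyond the scatter) and counts as large. The 3-aminothiophen-2-yl also compares poorly with the two six-membered groups, with an at least 2.4-fold higher number from compound 1 to compound 4 (0.39 log units; beyond the scatter) and with an at least 2.2-fold higher number from compound 2 to compound 4 (0.34 log units; beyond the scatter) so this position can move the number in either direction, depending on the group placed there. In this assay compound 4 gives > 10000 nM which is a limit of the assay and not a number: the limit of > 10000 nM in this assay, at which 1 of the 4 values shown sits.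

Compound 3 and compound 4 differ in both the substituent and its place on the thiophene, so the compounds shown cannot separate these two changes; a 5-aminothiophen-2-yl or a 3-bromothiophen-2-yl would do so. Also open, on these data alone, is how a thiophen-2-yl without any substituent would compare.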